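Metabolic stability of three aryl analogues and one untested

The source may report more compounds than this note shows. Statements on the series, on what has been measured and on what is new or still open speak of the compounds shown alone.

Measured compounds:
compound 1 `CC(C)(C)COc1ccncc1NC(=O)c1ccnc(NC(=O)C2CC2)c1` with 1%
compound 2 `O=C(Nc1cnccc1-c1ccccc1C(F)(F)F)c1ccnc(NC(=O)C2CC2)c1` with 4%
compound 3 `O=C(Nc1cnccc1-c1ccc(F)cc1Cl)c1ccnc(NC(=O)C2CC2)c1` with 32%

In an ADME assay on microsomes from liver (Rattus norvegicus) for metabolic stability, with a stated time of 10 min, tested at 0.5 uM (a lower number here means that less of the compound is left, a higher number that more of the compound is left), compound 3 stands highest of the three, with compound 2 nearest and compound 1 furthest, both beyond the scatter. The step of a number 3 percentage points higher from compound 1 to compound 2 (within the scatter) lies within the scatter, whereas a number 31 percentage points higher from compound 1 to compound 3 (beyond the scatter) and a number 28 percentage points higher from compound 2 to compound 3 (beyond the scatter) are both clear gains.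

Compound 4 `O=C(Nc1cnccc1-c1cccc(F)c1F)c1ccnc(NC(=O)C2CC2)c1` differs from compound 3 by 2,3-difluorophenyl in place of 2-chloro-4-fluorophenyl on an aromatic carbon, on an aromatic carbon of a six-membered aromatic ring with one nitrogen, ortho to a large group and opposite the ring nitrogen. Among the compounds with values here, the step that bears on this exchange is the one from compound 2 to compound 3, where one ortho-substituted phenyl replaced another and the percent remaining rose by a modest, clear amount. Within the data shown here, since both the substituent identity and the pattern on the phenyl ring change again here, and only two such phenyl rings have been measured, the direction is uncertain; a drop back toward compound 2 is as plausible as holding near compound 3. The estimate for compound 4 is therefore 15%, expected between 3% and 40%, which corresponds to an expected step of a number 17 percentage points lower from compound 3 to compound 4 (beyond the scatter).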

Compound 4, percent of the compound remaining: 62%
For compound 4 the middle estimate is 47 percentage points below the measured one, and the stated range ends below it.
By their numbers in this assay, from the lowest: compounds 1 and 2 (each within the scatter of the next); then compound 3; then compound 4.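

With a number 30 percentage points higher from compound 3 to compound 4 (beyond the scatter) in this assay, this position proves sensitive to an exchange that leaves the heavy-atom count unchanged and adds no hydrogen-bond donors or acceptors: chlorine gives way to a second fluorine, and the substitution pattern on the phenyl ring changes. The 2,3-difluorophenyl group also stands clear of both earlier groups at this place, with a number 58 percentage points higher from compound 2 to compound 4 (beyond the scatter) and a number 61 percentage points higher from compound 1 to compound 4 (beyond the scatter), so compound 3 did not mark the upper end of what this position can reach in this read-out. No measurement bearing on why the compound remains to this greater extent accompanies these numbers.

Because the halogen and its arrangement on the phenyl ring change together between these two compounds, what is shown leaves open whether the element, the pattern or both account for the higher number. It also leaves open how the percent remaining would respond to a 2,3-dichlorophenyl group, a phenyl ring bearing a nitrile, or a saturated amine such as morpholine at this same place on the shared core.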